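Adding a propyl chain to a naphthyl thiol sugar conjugate

A few compounds are considered here, and "the series" means these few. Any claim that something is new, unique, unknown or untested is made for them only; others in the source may bear on it.

Measured so far:
- compound 1 `O[C@@H]1[C@@H](O)[C@H](Oc2cc3ccccc3cc2S)OC[C@H]1O`: 145 uM
- compound 2 `Oc1ccc(S[C@@H]2OC[C@@H](O)[C@H](O)[C@H]2O)c2ccccc12`: 160 uM
- compound 3 `CCCSc1cccc2cccc(O[C@@H]3OC[C@@H](O)[C@H](O)[C@H]3O)c12`: 155 uM

Three sugar-linked naphthalene derivatives have been tested in a functional assay on T-24 cells (Homo sapiens) for antiproliferative activity, read by crystal violet staining, with a stated time of 96 h; on this read-out lower numbers stand for an effect already at smaller amounts and higher numbers for an effect only at larger amounts of compound. Compound 1 gives 145 uM in this assay, compound 2 gives 160 uM, and compound 3 gives 155 uM. Compound 1 carries the smallest of the three numbers, but its gaps to compound 3 and to compound 2 both lie within the usual scatter of this kind of measurement, so the three compounds cannot be told apart on these data.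

Compound 4 `CCCSc1cc2ccccc2cc1O[C@@H]1OC[C@@H](O)[C@H](O)[C@H]1O` has not yet been measured. It differs from compound 1 in one place: propyl in place of hydrogen on a sulfur. Among the compounds with values here, no pair of measured compounds differs by exactly this change, so there is no measured step to lean on. What can be said is that compound 3, which already carries a propylsulfanyl group on its own core, gives 155 uM, a number within scatter of compound 1.

On that basis the step from compound 1 to compound 4 in this assay is expected to be small, a 1.0-fold higher number from compound 1 to compound 4 (0.01 log units; within the scatter), with no direction beyond the scatter. Compound 4 is therefore estimated at 150 uM, with a plausible range from 80 uM to 280 uM.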

Compound 4, concentration for half-maximal effect: 70 uM
Beside the measured number, compound 4's estimate is 2.1-fold (0.33 log units) above it; measured number below the stated range.
By their numbers in this assay, from the lowest: compound 4; then compounds 1, 3 and 2 (each within the scatter of the next).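

Replacing the hydrogen on the sulfur with propyl gives, in this assay, a 2.1-fold lower number from compound 1 to compound 4 (0.32 log units; beyond the scatter) on the shared core, a modest change but one that lies beyond the usual scatter. Within the data shown here, the earlier compounds offered no single-change comparison and their numbers could not be told apart, so this is the first sign that what sits on this sulfur can shift the concentration needed for an antiproliferative effect, with the propylsulfanyl compound acting at the smaller amount. The data shown offer no measurement that explains this shift.

Going by these compounds, it remains open whether the effect depends on chain length, which a methyl group or a longer chain such as butyl or hexyl on the same sulfur would test, and whether a chain ending in an amine or a carboxylic acid would keep the lower number. Whether the same swap from sulfanyl to propylsulfanyl moves the number on a different core also remains unanswered.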